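The source may report more compounds than this note shows. Statements on the series, on what has been measured and on what is new or still open speak of the compounds shown alone.

For the measured compounds named here, compound 2 `Fc1ccc(-c2ncnc3c2cnn3CCN2CCCCC2)c(F)c1` is one of two compounds measured in an assay on HEK293 cells for displacement of a labelled ligand from Sigma non-opioid intracellular receptor 1 (Homo sapiens), read by scintillation counting, with a stated time of 120 min (on this read-out higher numbers stand for weaker inhibition and lower numbers for stronger inhibition), where compound 2 gives 93 nM. Going by the values given here, its companion is compound 1 `Clc1ccccc1-c1ncnc2c1cnn2CCN1CCCCC1`, which in this assay gives 76 nM; the single step recorded, a 1.2-fold higher number from compound 1 to compound 2 (0.09 log units; within the scatter), lies within the scatter, so the two numbers cannot be told apart.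

The next compound, compound 3 `c1cc(-c2ncnc3c2cnn3CCN2CCCCC2)ccn1`, has not yet been measured in this assay. It differs from compound 2 in one place: pyridin-4-yl in place of 2,4-difluorophenyl on an aromatic carbon. Among the compounds with values here, the one measured step bears only loosely on this change, since a 1.2-fold higher number from compound 1 to compound 2 (0.09 log units; within the scatter) exchanged one halogenated phenyl for another and left the number essentially where it was. Within the data shown here, nothing among the measured compounds shows what replacing the six-carbon ring by a ring carrying a hetero atom does here, so the expectation rests on weak ground.

The account therefore expects a modest weakening, as a step of about a 3.0-fold higher number from compound 2 to compound 3 (0.48 log units; beyond the scatter), and estimates that compound 3 will give 280 nM in this assay, within a range of 90 nM to 900 nM.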

Compound 3, inhibition constant: 1720 nM
The estimate for compound 3 lay 6.1-fold (0.79 log units) below the measured number, and the stated range ends below it.
By their numbers in this assay, from the lowest: compounds 1 and 2 (each within the scatter of the next); then compound 3.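

At this position, on an aromatic carbon of a six-membered aromatic ring with 2 nitrogen, the earlier exchange of one halogenated phenyl for another left the numbers indistinguishable, but the number in this assay proves far from indifferent to the ring that sits there: pyridin-4-yl brings an 18-fold higher number from compound 2 to compound 3 (1.27 log units; beyond the scatter) and likewise a 23-fold higher number from compound 1 to compound 3 (1.35 log units; beyond the scatter) in the two direct comparisons. Both steps are large and beyond the scatter, so compound 1 and compound 2 stand together, well apart from compound 3, and the exchange of a carbon-only ring for one with a hetero atom emerges as a far larger change here than the earlier swap of halogenated phenyl groups. The material at hand offers no evidence on why this replacement weakens inhibition so strongly.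

On these data alone, it remains open whether a plain phenyl ring would stay with compound 1 and compound 2 or fall toward compound 3, and whether pyridin-3-yl would produce a step of similar size. Also open, as far as these compounds go, is whether a chlorine or fluorine on the pyridin-4-yl ring would bring the number back toward those of the halogenated phenyl compounds.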